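The source may hold more compounds than are shown below. What is called first, only, known or untested is meant among the compounds shown, and "the series" means these compounds.

Within the data shown here, in a functional assay on MCF7 cells (Homo sapiens) for cytotoxicity, read by MTT assay, with a stated time of 48 h (a higher number here means a weaker inhibitor, a lower number a stronger inhibitor), compound 1 `Cc1n[nH]c2c1C(c1ccc(N(C)C)cc1)C(C(=O)NNC(N)=S)=C(N)N2` gives 5210 nM, the lower of the two numbers so far. Compound 2 `Cc1n[nH]c2c1C(c1ccc(N(C)C)cc1)C(C(=O)NNc1cc([N+](=O)[O-])ccc1[N+](=O)[O-])=C(N)N2` stands higher at 13000 nM. Among the measured compounds shown here, the only measured step, a 2.5-fold higher number from compound 1 to compound 2 (0.40 log units; beyond the scatter), replaces a group on an amine nitrogen and keeps the rest of the structure. Compound 3 `Cc1n[nH]c2c1C(c1ccc(N(C)C)cc1)C=C(N)N2` differs from compound 1 at another level: a hydrogen atom in place of a group of 7 heavy atoms (2 carbon, 3 nitrogen, 1 oxygen, 1 sulfur; no ring), on a double-bonded ring carbon, a hydrogen atom on a double-bonded ring carbon. For the measured compounds named here, no measured compound lacks this group, so the measured step is only an indirect guide. That one step, with compound 2 at 13000 nM, is the sole basis for expecting a modest move to a higher number in this assay, though a move either way remains possible. The expected change is a 2.7-fold higher number from compound 1 to compound 3 (0.43 log units; beyond the scatter). For compound 3 the estimated value is 14000 nM, with an expected range of 4500 nM to 45000 nM.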

Compound 3, half-maximal inhibitory concentration: 11200 nM
Compound 3: middle estimate off by 1.3-fold (0.10 log units), on the high side; the range from low to high includes it.
By their numbers in this assay, from the lowest: compound 1; then compounds 3 and 2 (each within the scatter of the next).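

In this assay, the double-bonded ring carbon now carries only a hydrogen atom, and losing the whole group of 7 heavy atoms gives a 2.1-fold higher number from compound 1 to compound 3 (0.33 log units; beyond the scatter), a modest step. The group is therefore not required for a measurable number, since compound 3 still gives 11200 nM. Compound 3 and compound 2 lie within the scatter of each other, so among these three only compound 1 stands apart. The compounds shown offer no measurement that would explain this step. From the compounds shown here alone, it remains open whether a smaller group on this carbon, such as a carboxylic acid or a simple primary amide, would keep the number of compound 1, and whether an oxygen in place of the sulfur in its group would do the same.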